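The source may hold more compounds than are shown below. What is called first, only, known or untested is meant among the compounds shown, and "the series" means these compounds.

Compound 2 `CCCn1ccc2c(NCc3ccccc3)cccc2c1=O` gives 2000 nM in a functional assay on CHO cells for positive allosteric modulation of metabotropic glutamate receptor 2 (Homo sapiens), read by scintillation counting and GTPgammaS binding, with a stated time of 30 min (on this read-out higher numbers stand for an effect only at larger amounts of compound and lower numbers for an effect already at smaller amounts), the highest number among the three measured compounds; compound 3 `CCCn1ccc2c(NCc3ccccc3Cl)cccc2c1=O` gives 200 nM and compound 1 `CCCn1ccc2c(NCCCc3ccccc3)cccc2c1=O` gives 158 nM. Compound 4 `CCCn1ccc2c(N(Cl)Cc3ccccc3)cccc2c1=O` differs from compound 2 by chloro in place of hydrogen on a nitrogen on an aromatic ring. Within the data shown here, none of the measured steps touches that nitrogen: a 13-fold higher number from compound 1 to compound 2 (1.10 log units; beyond the scatter) and a 1.3-fold higher number from compound 1 to compound 3 (0.10 log units; within the scatter) concern the chain, while a 10-fold lower number from compound 2 to compound 3 (1.00 log units; beyond the scatter) places chloro on an aromatic carbon rather than on the nitrogen. Among the measured compounds shown here, those steps give no direct guide, and no size of step in this assay can be derived with confidence in either direction. Compound 4 is expected to give 2000 nM, spanning 400 nM to 10000 nM. The expected step is no change at the digits printed from compound 2 to compound 4 (within the scatter). For the measured compounds named here, the range is kept wide: no comparable step exists.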

Compound 4, half-maximal effective concentration: 50100 nM
Estimate against measurement, compound 4: 25-fold (1.40 log units) below; the whole stated range lies below it.
By their numbers in this assay, from the lowest: compounds 1 and 3 (each within the scatter of the next); then compound 2; then compound 4.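

In this assay, replacing the hydrogen on this nitrogen on an aromatic ring with chloro carries a clear penalty: a 25-fold higher number from compound 2 to compound 4 (1.40 log units; beyond the scatter). Chloro on an aromatic carbon goes the opposite way, a 10-fold lower number from compound 2 to compound 3 (1.00 log units; beyond the scatter), so within these two pairs the direction of the step depends on where chloro sits. No measurement shown bears on the reason for the rise at the nitrogen.

On these data alone, whether the rise comes from losing that hydrogen or is specific to chloro remains open; a methyl or an acetyl on the same nitrogen would separate the two.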